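A Sulfonamide Replaces the Difluorophenyl on the Core

The compounds below may be only part of what the source reports. "The series", "measured", "known", "first", "only" and "open" are said of these compounds alone.

Of the compounds shown here, three sharing one core have been measured in an ADME assay on HFF cells (Homo sapiens) for cytotoxicity, read by MTT assay, with a stated time of 72 h; a higher number here means a weaker inhibitor, a lower number a stronger inhibitor. Compound 1 `CC(C)(C)c1cn(C[C@H](O)[C@H]2OC(=O)C(OCc3ccccc3)=C2OCc2ccccc2)nn1` gives 13300 nM. Compound 2 `O=C1O[C@H]([C@@H](O)Cn2cc(-c3cccc(O)c3)nn2)C(OCc2ccccc2)=C1OCc1ccccc1` gives 39000 nM. Compound 3 `O=C1O[C@H]([C@@H](O)Cn2cc(-c3cc(F)cc(F)c3)nn2)C(OCc2ccccc2)=C1OCc1ccccc1` reaches only the limit of this assay, > 100000 nM, so no number is known for it. Among the values shown, compound 3 stands as the weakest inhibitor: the step of an at least 7.5-fold higher number from compound 1 to compound 3 (0.87 log units; beyond the scatter) and the step of an at least 2.5-fold higher number from compound 2 to compound 3 (0.40 log units; beyond the scatter) both run toward it, while a 2.9-fold higher number from compound 1 to compound 2 (0.47 log units; beyond the scatter) is the smaller change.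

Compound 4 `O=C1O[C@H]([C@@H](O)Cn2cc(CNS(=O)(=O)c3ccc(F)cc3)nn2)C(OCc2ccccc2)=C1OCc1ccccc1` differs from compound 3 in one place: (((4-fluorophenyl)sulfonyl)amino)methyl in place of 3,5-difluorophenyl on an aromatic carbon. Among the compounds with values here, none of the measured steps involves a (((4-fluorophenyl)sulfonyl)amino)methyl group, so none bears directly on this change; the two steps out of compound 1 both weakened inhibition, and compound 3 sits at the limit of > 100000 nM in this assay, at which 1 of the 3 values shown sits, so a further weakening in this assay would leave it at the limit. Compound 4 is expected to give 80000 nM, within 30000 nM to 200000 nM. That estimate means an expected at least 1.2-fold lower number from compound 3 to compound 4 (0.09 log units; that floor lies within the scatter), with a real chance that only a limit is reported.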

Compound 4, half-maximal inhibitory concentration: 30 nM
Beside the measured number, compound 4's estimate is 2700-fold (3.43 log units) above it, outside the stated range (below it).
By their numbers in this assay, from the lowest: compound 4; then compound 1; then compound 2. At a limit, above all of these: compound 3.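

In this assay, this aromatic carbon of the five-membered aromatic ring with 3 nitrogen proves able to move the number sharply downward, and compound 4 gives the lowest value of the series, with an at least 3300-fold lower number from compound 3 to compound 4 (3.52 log units; beyond the scatter), a 1300-fold lower number from compound 2 to compound 4 (3.11 log units; beyond the scatter) and a 440-fold lower number from compound 1 to compound 4 (2.65 log units; beyond the scatter). A six-membered aromatic ring of carbon only is present in compound 2, compound 3 and compound 4 alike, so that ring alone does not set the number. The first of these steps is only a floor, since the value of compound 3 is a limit and not a number: the limit of > 100000 nM in this assay, at which 1 of the 4 values shown sits.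

Which part of the (((4-fluorophenyl)sulfonyl)amino)methyl group carries the step stays open, whether the sulfonyl, the amino hydrogen, the methyl link or the fluorine. Also open, going by these compounds, is how a carboxamide link, an unsubstituted phenyl on the sulfonyl or a longer chain would read here.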